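The source may hold more compounds than are shown below. What is called first, only, known or untested is meant among the compounds shown, and "the series" means these compounds.

Compound 1 `CCOc1ccc(C)c(-c2cccc(COc3ccc(OCC(=O)O)c(F)c3)c2)c1` gives 220 nM in a functional assay on CHO cells for agonist activity at Free fatty acid receptor 1 (Homo sapiens), read by FLIPR and calcium flux (on this read-out lower numbers stand for an effect already at smaller amounts and higher numbers for an effect only at larger amounts of compound), the lowest of the two numbers recorded so far. Among the measured compounds shown here, compound 2 `CCCOc1ccc(C)c(-c2cccc(COc3ccc(OCC(=O)O)c(F)c3)c2)c1` gives 610 nM; the one measured step, a 2.8-fold higher number from compound 1 to compound 2 (0.44 log units; beyond the scatter), is the only guide available. Compound 3 `Cc1ccc(OCC2CCC2)cc1-c1cccc(COc2ccc(OCC(=O)O)c(F)c2)c1` differs from compound 1 by cyclobutyl in place of methyl on a saturated chain carbon bound to an oxygen on an aromatic ring. For the measured compounds named here, that change is larger than the one from compound 1 to compound 2 at the same chain, so a higher number beyond the scatter is expected, probably of a similar or somewhat greater size, as a 2.7-fold higher number from compound 1 to compound 3 (0.44 log units; beyond the scatter). Compound 3 is therefore estimated at 600 nM, expected between 220 nM and 1800 nM.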

Compound 3, half-maximal effective concentration: 1530 nM
Beside the measured number, compound 3's estimate is 2.6-fold (0.41 log units) below it, within the range that was stated.
By their numbers in this assay, from the lowest: compound 1; then compound 2; then compound 3.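

At the saturated chain carbon bound to an oxygen on an aromatic ring, cyclobutyl in place of methyl gives a 7.0-fold higher number from compound 1 to compound 3 (0.84 log units; beyond the scatter), and cyclobutyl in place of ethyl gives a 2.5-fold higher number from compound 2 to compound 3 (0.40 log units; beyond the scatter). Across these three compounds, the number rises with each added carbon in this group, none goes against that order, and the ring brings no recovery. Nothing available explains these changes. Still open, from the compounds shown here alone, is whether a methoxy group at this oxygen would give a lower number than compound 1. Also open, going by these compounds, is how a cyclopropylmethoxy group or an amine-bearing chain would behave here.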